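The compounds below may be only part of what the source reports. "The series", "measured", "known", "first", "only" and "open" are said of these compounds alone.

Measured so far:
- compound 1 `O=C1CCCC/C1=C\c1ccc(OC(=O)c2ccc(Cl)cc2)cc1`: 3330 nM
- compound 2 `Cc1ccc(C(=O)Oc2ccc(/C=C3\CCCCC3=O)cc2)cc1`: 44800 nM

In a functional assay on L1210 cells (Mus musculus) (a lower number here means a stronger inhibitor, a higher number a weaker inhibitor), compound 2 at 44800 nM holds the higher of the two numbers, which makes it the weaker inhibitor of the pair. Among the measured compounds shown here, its only measured neighbour is compound 1, and the link between them is a 13-fold higher number from compound 1 to compound 2 (1.13 log units; beyond the scatter), a large step with methyl in place of chloro on an aromatic carbon.

Next in line is compound 3 `COc1ccc(C(=O)Oc2ccc(/C=C3\CCCCC3=O)cc2)cc1`, which differs from compound 2 by methoxy in place of methyl on an aromatic carbon, or 4-methylphenyl to 4-methoxyphenyl.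

For the measured compounds named here, only one measured step bears on this change, a 13-fold higher number from compound 1 to compound 2 (1.13 log units; beyond the scatter), and it shows that a swap of this group can move the number well beyond the scatter. Going by the values given here, no measured compound carries methoxy, so the direction rests on little. The working expectation in this assay is a modest move to a lower number, leaving compound 3 within the span set by the first two compounds. The expected step is a 2.5-fold lower number from compound 2 to compound 3 (0.40 log units; beyond the scatter), and it remains uncertain. The estimate for compound 3 is 18000 nM, with an expected range of 4000 nM to 70000 nM.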

Compound 3, half-maximal inhibitory concentration: 43400 nM
For compound 3 the middle estimate is 2.4-fold (0.38 log units) below the measured one; the measured number falls inside the stated range.
By their numbers in this assay, from the lowest: compound 1; then compounds 3 and 2 (each within the scatter of the next).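

In this assay, a 1.0-fold lower number from compound 2 to compound 3 (0.01 log units; within the scatter), so the change from 4-methylphenyl to 4-methoxyphenyl, on an aromatic carbon para to a large group, does not separate these two compounds, even though methoxy brings one hydrogen-bond acceptor that methyl lacks. With chloro at the same place, a 13-fold higher number from compound 1 to compound 3 (1.12 log units; beyond the scatter), a step of about the same size as a 13-fold higher number from compound 1 to compound 2 (1.13 log units; beyond the scatter), so the large step is now seen with two different replacements of chloro, not with methyl alone, and among these three compounds compound 1 stands apart while compound 2 and compound 3 stay together. No measurement on these compounds offers an explanation for this result.

The compounds shown leave open whether the lower number of compound 1 belongs to chloro specifically or would also appear with bromo, fluoro, trifluoromethyl or nitrile at this place. Also open, from the compounds shown here alone, is whether a carboxylic acid or an amine here would stay with compound 2 and compound 3 or move toward compound 1.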